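A few compounds are considered here, and "the series" means these few. Any claim that something is new, unique, unknown or untested is made for them only; others in the source may bear on it.

In a functional assay on the whole organism (strain Wistar) for inhibition, with Rattus norvegicus as the target, read by paw edema, with stated times of 60 min and 3 h, at a dose of 100 mg/kg by the oral route (a lower number here means less inhibition, a higher number more inhibition at the dose given (going by the name of the read-out)), compound 2 `CCN(CC)C(=O)CC1CCc2cc(OC)c(OC)cc21` gives 37.7%. Among the compounds with values here, it stands alongside compound 1 `COc1cc2c(cc1OC)C(CC(N)=O)CC2`, the only other measured compound, which gives 30.4% in this assay; the step of a number 7.3 percentage points higher from compound 1 to compound 2 (within the scatter) is within the scatter. Compound 3 `COc1cc2c(cc1OC)C(CC(=O)NC(C)C)CC2` differs from compound 2 by isopropylamino in place of diethylamino on a carbonyl carbon. Within the data shown here, the only measured step that bears on this change is the one from compound 1 to compound 2, which also altered the amino group on the carbonyl carbon and stayed within the scatter, so no step beyond the scatter is expected here. Compound 3 is therefore expected to give 35%, between 20% and 50%, an expected step of a number 2.7 percentage points lower from compound 2 to compound 3 (within the scatter).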

Compound 3, a percentage reported as inhibition, in the whole organism at one dose (the size of the read-out at that dose, not a potency): 30.4%
Compound 3: middle estimate off by 4.6 percentage points, on the high side; low and high end bracket the measured number.
By their numbers in this assay, from the lowest: compounds 1, 3 and 2 (each within the scatter of the next).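

In this assay, the step of a number 7.3 percentage points lower from compound 2 to compound 3 (within the scatter) for isopropylamino in place of diethylamino is within the scatter. Isopropyl in place of hydrogen on the amide-type nitrogen gives no change at the digits printed from compound 1 to compound 3 (within the scatter), so none of the three groups on this carbonyl carbon is set apart from the others by a step beyond the scatter. No measurement shown gives a reason for these numbers. Open, as far as these compounds go, is whether a piperidine amide, or a carboxylic acid in place of the amide, would give a step beyond the scatter.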